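The source may hold more compounds than are shown below. What is called first, only, known or untested is meant among the compounds shown, and "the series" means these compounds.

Among the compounds with values here, only two compounds have been tested so far, and one of them gives nothing to compare. In a functional assay on KB cells (Homo sapiens) for inhibition, read by MTT assay, with a stated time of 24 h, tested at 0.1 ug/mL (a lower number here means less inhibition of growth, a higher number more inhibition of growth at the concentration tested), compound 1 (`O=C(CCCCC(S)CCS)Nc1ccc([N+](=O)[O-])c(C(F)(F)F)c1`) is recorded as "not active" (no number reported) and carries no figure. Within the data shown here, compound 2 (`CC(=O)SCCC(CCCCC(=O)Nc1ccccc1)SC(C)=O`), with its two thioacetate-bearing chain, gives 7.24% in this assay and this is the only number available, so it cannot yet be ranked against anything. It is a modest reading on a scale where higher means more growth inhibition.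

Compound 3 (`CC(=O)SCCC(CCCCC(=O)Nc1ccc(Cl)cc1)SC(C)=O`) keeps all of compound 2 except for one spot on the aromatic ring. The change is chloro in place of hydrogen on an aromatic carbon and amounts to chloro in place of hydrogen on an aromatic carbon, which turns phenyl to 4-chlorophenyl.

Among the measured compounds shown here, no measured pair of compounds shows what a swap of this kind does here, so any forecast is loose. The expected step of a number 2.8 percentage points higher from compound 2 to compound 3 (within the scatter) is a small upward one that stays within the usual scatter. In this assay the estimate for compound 3 is 10% with a range from 2% to 22% expected to cover most repeat measurements.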

Compound 3, percent growth inhibition at one concentration: 11.4%
Compound 3: the middle estimate sits 1.4 percentage points below what was measured, within the range that was stated.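

Within the data shown here, this is the first measured pair for this kind of change: in this assay, putting chloro in place of hydrogen on an aromatic carbon, para to a large group, gives a number 4.2 percentage points higher from compound 2 to compound 3 (within the scatter). Turning phenyl into 4-chlorophenyl therefore leaves the two compounds indistinguishable in this growth-inhibition test, and a single pair cannot show a real effect of chloro at this position, in either direction. No available measurement bears on why the reading came out as it did.

As far as these compounds go, it remains open whether a different group at this same position, such as a methoxy group, a nitrile or a carboxylic acid, would produce a step that clearly exceeds the scatter. The role of the two thioacetate groups also remains unresolved, since compound 1 differs from compound 2 and compound 3 in more than one place and carries no number, so a pair with free thiols and an otherwise unchanged anilide would be needed to separate that change from the ring substituents.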